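Fluoro added to the dimethylphenyl ring of compound 3

This account rests on a few compounds, and the source may have more. Where it says the series, first, only, none or still open, it means among the compounds named here.

Three compounds built on one shared core have been run in an assay on microsomes from liver for inhibition of 3-hydroxy-3-methylglutaryl-coenzyme A reductase (Rattus norvegicus); on this read-out higher numbers stand for weaker inhibition and lower numbers for stronger inhibition. In this assay compound 1 `Cc1cccc(-c2nc(C(F)(F)F)n(CC[C@@H](O)C[C@@H](O)CC(=O)O)c2-c2ccc(F)cc2)c1` gives 29 nM, compound 2 `Cc1ccc(-c2nc(C(F)(F)F)n(CC[C@@H](O)C[C@@H](O)CC(=O)O)c2-c2ccc(F)cc2)cc1` gives 43 nM, and compound 3 `Cc1cc(C)cc(-c2nc(C(F)(F)F)n(CC[C@@H](O)C[C@@H](O)CC(=O)O)c2-c2ccc(F)cc2)c1` gives 24 nM. The three differ only in the methyl pattern on one phenyl ring, and none of the steps between them leaves the scatter: a 1.5-fold higher number from compound 1 to compound 2 (0.17 log units; within the scatter), a 1.2-fold lower number from compound 1 to compound 3 (0.08 log units; within the scatter), a 1.8-fold lower number from compound 2 to compound 3 (0.25 log units; within the scatter). Compound 3 has the lowest of the three numbers, but its distances to compound 1 and compound 2 are both within the scatter, so no order among them can be read.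

Compound 4 `Cc1cc(-c2nc(C(F)(F)F)n(CC[C@@H](O)C[C@@H](O)CC(=O)O)c2-c2ccc(F)cc2)cc(C)c1F` is the next member. Relative to compound 3 the change is fluoro in place of hydrogen on an aromatic carbon. For the measured compounds named here, no measured pair contains a fluoro on this ring, so the three steps bear only indirectly, by showing that small changes of substitution on this ring have so far moved this assay by amounts within the scatter. On that basis no step beyond the scatter is expected in either direction. The estimated step is a 1.0-fold higher number from compound 3 to compound 4 (0.02 log units; within the scatter). Compound 4 is therefore expected to give about 25 nM in this assay, with a range from 10 nM to 60 nM.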

Compound 4, half-maximal inhibitory concentration: 32 nM
The estimate for compound 4 lay 1.3-fold (0.11 log units) below the measured number; the measured number falls inside the stated range.
By their numbers in this assay, from the lowest: compounds 3, 1, 4 and 2 (each within the scatter of the next).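

Fluoro on this aromatic carbon, ortho to two methyl groups and para to a large group, gives the first reading of a non-carbon substituent on this ring in this assay, and the step is a 1.3-fold higher number from compound 3 to compound 4 (0.12 log units; within the scatter). The 4-fluoro-3,5-dimethylphenyl ring also stays level with both single-methyl rings, with a 1.3-fold lower number from compound 2 to compound 4 (0.13 log units; within the scatter) against the 4-methylphenyl ring and a 1.1-fold higher number from compound 1 to compound 4 (0.04 log units; within the scatter) against the 3-methylphenyl ring, so the four substitution patterns shown cannot be ordered. No measurement is available that would explain these small steps.

As far as these compounds go, it remains open whether any group on this carbon can move the number beyond the scatter, for instance an amine, a carboxylic acid or a longer chain such as a butyl group in place of the fluoro. All four compounds also carry the same trifluoromethyl group on the shared core, so the response of this assay to a change there, such as a nitrile in its place, is also unknown.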